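The source may hold more compounds than are shown below. What is called first, only, known or untested is meant among the compounds shown, and "the series" means these compounds.

Measured compounds and their values:

Compound 1, `O=C1NC(=S)S/C1=C\C=C\c1ccccc1`, in an assay on isolated protein for inhibition of protein tyrosine phosphatase type IVA 3 (Homo sapiens), tested at 5 ug/mL (on this read-out lower numbers stand for less inhibition and higher numbers for more inhibition at the one concentration tested (going by the name of the read-out)), gives 37.4%.
Compound 2, `COc1ccccc1/C=C/C=C1\SC(=S)NC1=O`, in this assay gives 41.7%.

Among the compounds with values here, compound 2 and compound 1 are the only two measured members, and their two numbers lie within the scatter of each other: the single measured step, a number 4.3 percentage points higher from compound 1 to compound 2 (within the scatter), is not a real change. Compound 2 therefore stands level with compound 1 rather than above it.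

The unmeasured compound 3, `O=C1NC(=S)S/C1=C\C=C\c1ccccc1Cl`, differs from compound 2 in one place: chloro in place of methoxy on an aromatic carbon. Within the data shown here, the only step on record, from compound 1 to compound 2, bears on it indirectly, since it shows what adding methoxy at this aromatic carbon did, and that step stayed within the scatter. Among the measured compounds shown here, no measured pair shows what a chloro group at this place does, so the expectation rests on the observation that the one substituent tried there left the inhibition unchanged. Compound 3 is accordingly expected to move by a number 1.7 percentage points lower from compound 2 to compound 3 (within the scatter), a step not beyond the scatter. The estimate for compound 3 is 40%, with a range from 25% to 55%.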

Compound 3, a percentage reported as inhibition, at one concentration (the size of the read-out at that concentration, not a potency): 53.9%
For compound 3 the middle estimate is 13.9 percentage points below the measured one; low and high end bracket the measured number.
By their numbers in this assay, from the lowest: compounds 1 and 2 (each within the scatter of the next); then compound 3.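

In this assay, chloro in place of methoxy on this aromatic carbon gives a number 12.2 percentage points higher from compound 2 to compound 3 (beyond the scatter) and chloro in place of hydrogen gives a number 16.5 percentage points higher from compound 1 to compound 3 (beyond the scatter) at the same place, so both steps show a modest but real change. Until now, the only comparison at this position, between hydrogen and methoxy, had shown no real difference, so the position could have seemed indifferent to what it carried; the chloro group shows that the choice of substituent here can alter the inhibition read at the one concentration tested. Nothing available explains why chloro differs from methoxy and hydrogen at this place.

The compounds shown leave open whether the change is particular to chloro or would also appear with bromo, fluoro, an amine or a carboxylic acid at this place, and whether chloro would give a similar step on another carbon of the six-membered aromatic ring. They also leave open how far these single-concentration percentages reflect potency, which a full concentration series would be needed to establish.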